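This account rests on a few compounds, and the source may have more. Where it says the series, first, only, none or still open, it means among the compounds named here.

Measured compounds:
compound 1 `O=C(N/N=C/c1cccc(F)c1)c1cccnc1Nc1cccc(C(F)(F)F)c1`: 52.8% in a functional assay on the whole organism (strain Wistar) for inhibition, with Rattus norvegicus as the target, read by paw edema, with a stated time of 2 h, at a dose of 10 mg/kg by the intraperitoneal route; a lower number here means less inhibition, a higher number more inhibition at the dose given (going by the name of the read-out)
compound 2 `O=C(N/N=C/c1cccc(O)c1)c1cccnc1Nc1cccc(C(F)(F)F)c1`: 65.4% in this assay
compound 3 `O=C(N/N=C/c1ccc(O)cc1)c1cccnc1Nc1cccc(C(F)(F)F)c1`: 68% in this assay

Compound 3 holds the highest of the three numbers. Its nearest neighbour is compound 2, and the step of a number 2.6 percentage points higher from compound 2 to compound 3 (within the scatter) is within the scatter, so no order between compound 2 and compound 3 can be claimed. The furthest is compound 1, where the step of a number 15.2 percentage points higher from compound 1 to compound 3 (beyond the scatter) is beyond the scatter.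

The next compound, compound 4 `O=C(N/N=C/c1cccnc1)c1cccnc1Nc1cccc(C(F)(F)F)c1`, is not yet measured. The change from compound 3 is pyridin-3-yl in place of 4-hydroxyphenyl on a carbon with a double bond to nitrogen.

Among the compounds with values here, two measured steps bear on this. Both a number 12.6 percentage points higher from compound 1 to compound 2 (beyond the scatter) and a number 15.2 percentage points higher from compound 1 to compound 3 (beyond the scatter) run from a fluoro-bearing ring to a hydroxy-bearing ring and both are modest rises beyond the scatter, so the hydroxy group seems tied to the higher numbers in this set. Within the data shown here, compound 4 gives up that hydroxy while keeping one acceptor in the ring nitrogen; no measured step shows this exact exchange. A modest fall from compound 3 is therefore expected, landing nearer compound 1, with the estimated step of a number 11 percentage points lower from compound 3 to compound 4 (beyond the scatter).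

Compound 4 is expected to give 57% in this assay, within 44% to 69%.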

Compound 4, a percentage reported as inhibition, in the whole organism at one dose (the size of the read-out at that dose, not a potency): 62.4%
The estimate for compound 4 lay 5.4 percentage points below the measured number, within the range that was stated.
By their numbers in this assay, from the lowest: compounds 1, 4, 2 and 3 (each within the scatter of the next, the first and the last beyond it).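

At this place, on a carbon with a double bond to nitrogen, pyridin-3-yl stands in for either hydroxyphenyl ring in this assay without a step that can be told from the scatter: a number 5.6 percentage points lower from compound 3 to compound 4 (within the scatter) and a number 3 percentage points lower from compound 2 to compound 4 (within the scatter) are both within it. Pyridin-3-yl carries 0 hydrogen-bond donors, so the earlier link between the hydroxy group and the higher numbers no longer holds as a requirement, and compound 4 is the compound that goes against it. At the same time, a number 9.6 percentage points higher from compound 1 to compound 4 (within the scatter) is also within the scatter, so compound 4 cannot be separated from the fluoro compound either, and this change gives no clean grouping of the four compounds.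

No measurement in hand gives a reason for these numbers.

From the compounds shown here alone, whether a ring nitrogen at another place, as in pyridin-4-yl, would read the same in this assay remains open. Also open, going by these compounds, is how a carboxylic acid or an amine on this ring, or a saturated ring such as piperidine in place of the aromatic one, would fare at this place.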